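The source may report more compounds than this note shows. Statements on the series, on what has been measured and on what is new or still open speak of the compounds shown alone.

Compound 1, `Cc1ccc(-c2nc3ccccc3s2)cc1NC(=O)c1cc([N+](=O)[O-])c(N2CCCCC2)cc1Cl`, was examined in an ADME assay on Raji cells (Homo sapiens) for cytotoxicity, with a stated time of 72 h; on this read-out lower numbers stand for an effect already at smaller amounts and higher numbers for an effect only at larger amounts of compound. In this assay compound 1 gives > 25000 nM, which is a limit of the assay rather than a number. Among the three measured compounds, compound 1 stands at the limit of > 25000 nM in this assay, at which 2 of the 3 values shown sit. Compound 2, `O=C(Nc1cc(-c2nc3ccccc3o2)ccc1F)c1cc([N+](=O)[O-])ccc1Cl`, likewise reaches only a limit in this assay, where compound 2 gives > 25000 nM. Within the data shown here, compound 3, `O=C(Nc1nc(-c2cccc(F)c2)cs1)c1cc([N+](=O)[O-])ccc1Cl`, is the one compound with a number, and in this assay compound 3 gives 11000 nM. Among the measured compounds shown here, no two of the measured compounds differ in one place alone, so no single step between them can be read from these values.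

Compound 4, `Cc1ccc(-c2nc3ccccc3s2)cc1NC(=O)c1cc([N+](=O)[O-])c(N(C)C)cc1Cl`, has not yet been measured. It differs from compound 1 in one place: dimethylamino in place of piperidin-1-yl on an aromatic carbon. Compound 1 gives > 25000 nM, a limit, and the step to compound 4 in this assay is expected to stay within the scatter of repeated measurements, in no direction beyond it. The expected step is a number no higher from compound 1 to compound 4 (the limit leaves the size open). For compound 4 the estimate is 25000 nM, with a range from 10000 nM to 60000 nM. For compound 4 a further limit rather than a number is expected as the most likely outcome.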

Compound 4, half-maximal effective concentration: > 25000 nM
Compound 4: no number, only a limit; the forecaster's own chance of this, stated with the estimate: 70%; the middle value lies on the limit itself.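

In this assay compound 4 gives > 25000 nM, which is a limit of the assay and not a number. Compound 1 likewise stands at a limit, and the step between compound 1 and compound 4 cannot be read. The compounds shown leave open whether dimethylamino and piperidin-1-yl differ at all in this assay.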